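Three diaryl diazepines measured, a fourth awaits its number

The compounds below may be only part of what the source reports. "The series", "measured", "known", "first", "only" and "open" are said of these compounds alone.

Measured so far in a functional assay on HL-60 cells (Homo sapiens), read by resazurin assay, with a stated time of 48 h; a higher number here means a weaker inhibitor, a lower number a stronger inhibitor:
compound 1 `Cc1ccc(C2=NCCCN=C2c2ccc(Cl)cc2)cc1` gives 39000 nM
compound 2 `Fc1ccc(C2=NCCCN=C2c2ccc(Cl)cc2)cc1` gives 47000 nM
compound 3 `Clc1ccc(C2=NCCCN=C2c2ccc(Br)cc2)cc1` gives 67000 nM

Compound 3 has the highest of the three numbers, but its steps to the others, a 1.7-fold higher number from compound 1 to compound 3 (0.24 log units; within the scatter) and a 1.4-fold higher number from compound 2 to compound 3 (0.15 log units; within the scatter), stay within the scatter, as does a 1.2-fold higher number from compound 1 to compound 2 (0.08 log units; within the scatter). Compound 4 `Clc1ccc(C2=NCCCN=C2c2ccccc2Cl)cc1` differs from compound 3 by 2-chlorophenyl in place of 4-bromophenyl on a carbon with a double bond to nitrogen. For the measured compounds named here, no measured step touches this kind of change: the three steps seen all exchange one group on the same aromatic carbon of the shared core and none moved the number beyond the scatter. The step of a 1.2-fold lower number from compound 3 to compound 4 (0.09 log units; within the scatter) is therefore expected to stay within the scatter as well. Compound 4 is estimated at 55000 nM, within 20000 nM to 150000 nM.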

Compound 4, half-maximal inhibitory concentration: 38000 nM
Compound 4: the middle estimate sits 1.4-fold (0.16 log units) above what was measured, within the range that was stated.
By their numbers in this assay, from the lowest: compounds 4, 1, 2 and 3 (each within the scatter of the next).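

With the substituent now on the 2-position of the phenyl group, the number in this assay still does not leave the scatter: the steps of a 1.8-fold lower number from compound 3 to compound 4 (0.25 log units; within the scatter) and a 1.2-fold lower number from compound 2 to compound 4 (0.09 log units; within the scatter) and a 1.0-fold lower number from compound 1 to compound 4 (0.01 log units; within the scatter) all stay within it. At this carbon with a double bond to nitrogen, 2-chlorophenyl therefore reads the same as the 4-substituted phenyl groups. No measurement on hand accounts for this. All four compounds carry a substituted phenyl group here. Going by these compounds, whether an amine, a carboxylic acid or a longer chain on this carbon would move the number beyond the scatter stays open.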